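Series notes: compound 2 to compound 4 in the cell assay

The source may hold more compounds than are shown below. What is called first, only, known or untested is meant among the compounds shown, and "the series" means these compounds.

Three compounds have numbers in a functional assay on U-87MG ATCC cells for inhibition, with U-87 MG (Homo sapiens) as the target, read by MTT assay, with a stated time of 72 h; on this read-out lower numbers stand for stronger inhibition and higher numbers for weaker inhibition. Compound 1 `Oc1c(C(Nc2ccccc2)c2ccccc2)ccc2cccnc12` gives > 10000 nM in this assay, which is a limit of the assay and not a number. Compound 2 `Cc1ccc(C(Nc2ccccn2)c2ccc3cccnc3c2O)cc1` likewise gives > 10000 nM, again a limit of the assay rather than a measured number. Going by the values given here, compound 3 `Oc1c(C(c2ccc(C(F)(F)F)cc2)N2CCCCC2)ccc2ccoc12` is the one compound with a measured value, at 5000 nM in this assay. Among the compounds with values here, compound 2 therefore stands at the limit of > 10000 nM in this assay, at which 2 of the 3 values shown sit, and no step between measured compounds is available to calibrate any change from it.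

Compound 4 `COc1cccc(C(Nc2ccccn2)c2ccc3cccnc3c2O)c1` is not yet measured. It differs from compound 2 by 3-methoxyphenyl in place of 4-methylphenyl on a saturated chain carbon bound to an aromatic carbon and a nitrogen on an aromatic ring. Within the data shown here, no measured step in the shared core tells how much this kind of exchange moves the read-out; the only guide is that compound 2 sits at the limit and that the one numbered compound, compound 3, is weak.

The step from compound 2 to compound 4 is expected to be small or none beyond the scatter, as a step that the limit leaves unreadable from compound 2 to compound 4. Compound 4 is accordingly expected to come out around 12000 nM in this assay, with a range from 4000 nM to 30000 nM, and a real chance that it too returns only a limit.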

Compound 4, half-maximal inhibitory concentration: 11900 nM
For compound 4 the middle estimate is 1.0-fold (0.00 log units) above the measured one; the range from low to high includes it.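

No step can be read from compound 2 to compound 4, because compound 2 carries only a limit of the assay and not a number: the limit of > 10000 nM in this assay, at which 2 of the 4 values shown sit.

The compounds shown leave open how far 3-methoxyphenyl in place of 4-methylphenyl moves the read-out in this assay on the shared core.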